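The source may hold more compounds than are shown below. What is called first, only, known or untested is meant among the compounds shown, and "the series" means these compounds.

Measured compounds:
compound 1 `O=C(/C=C/c1ccc2c(c1)B(O)OC2)c1ccc(Cl)cc1` – 7900 nM
compound 2 `O=C(/C=C/c1ccc2c(c1)B(O)OC2)c1ccc(Br)cc1` – 9500 nM
compound 3 `Cc1cccc(C(=O)/C=C/c2ccc3c(c2)B(O)OC3)c1` – 4500 nM

All three share the same core and differ only in the aryl ketone. In a functional assay on MDA-MB-231 cells (Homo sapiens) for cytotoxicity, read by MTT assay, with a stated time of 48 h (a lower number here means a stronger inhibitor, a higher number a weaker inhibitor), compound 1 gives 7900 nM and compound 2 gives 9500 nM; the halogen swap reads a 1.2-fold higher number from compound 1 to compound 2 (0.08 log units; within the scatter). Compound 3, with the 3-methylphenyl, gives 4500 nM, the lowest number of the three; the two steps that lead to it read a 1.8-fold lower number from compound 1 to compound 3 (0.24 log units; within the scatter) and a 2.1-fold lower number from compound 2 to compound 3 (0.32 log units; beyond the scatter), so it stands apart from compound 2 only.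

The next compound is compound 4 `Nc1cccc(C(=O)/C=C/c2ccc3c(c2)B(O)OC3)c1`. The change from compound 3 is amino in place of methyl on an aromatic carbon. Among the measured compounds shown here, no measured step touches this position with a change of this kind: the two steps to compound 3 replace the whole aryl group, and the step from compound 1 to compound 2 swaps halogens elsewhere. Nothing in the measured set therefore argues for a step in either direction in this assay beyond the scatter.

Compound 4 is expected near compound 3, at 5000 nM (range 1800 nM to 14000 nM), which corresponds to an estimated step of a 1.1-fold higher number from compound 3 to compound 4 (0.05 log units; within the scatter).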

Compound 4, half-maximal inhibitory concentration: 3200 nM
Beside the measured number, compound 4's estimate is 1.6-fold (0.19 log units) above it; the measured number falls inside the stated range.
By their numbers in this assay, from the lowest: compounds 4, 3, 1 and 2 (each within the scatter of the next, the first and the last beyond it).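

In this assay, the first change made at this position on the 3-substituted phenyl, amino in place of methyl, reads a 1.4-fold lower number from compound 3 to compound 4 (0.15 log units; within the scatter), so entering a hydrogen-bond donor and acceptor here moves the number no further than the scatter. Compound 4 separates from both halogen compounds, with a 3.0-fold lower number from compound 2 to compound 4 (0.47 log units; beyond the scatter) and a 2.5-fold lower number from compound 1 to compound 4 (0.39 log units; beyond the scatter), both beyond the scatter, whereas compound 3 separated from compound 2 only; each of these two steps replaces the whole aryl group, so the place of the group and its identity cannot be told apart. No measurement on hand explains any of these steps.

Going by these compounds, whether a hydroxyl or a carboxylic acid on this aromatic carbon would stay within the scatter of the amino group remains open. So does the effect of an amino group on the aromatic carbon that carries chloro or bromo in compound 1 and compound 2.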